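Methylating the Ring Urea Nitrogen of a Macrocyclic Acylsulfonamide

A few compounds are considered here, and "the series" means these few. Any claim that something is new, unique, unknown or untested is made for them only; others in the source may bear on it.

In an in vivo ADME assay on the whole organism (strain Sprague-Dawley) for pharmacokinetics, with Rattus norvegicus as the target, at a dose of 2 mg/kg by the intravenous route (a higher number here means that more of the compound sits outside the plasma, a lower number that more of the compound stays in the plasma), compound 1 `COc1ccc2c(O[C@@H]3C[C@H]4C(=O)N[C@]5(C(=O)NS(=O)(=O)C6CC6)C[C@H]5/C=C\CCCCCNC(=O)N4C3)cc(-c3nc(C(C)C)cs3)nc2c1` gives 1.46 L/kg, and compound 2 `COc1ccc2c(O[C@@H]3C[C@H]4C(=O)N[C@]5(C(=O)NS(=O)(=O)C6CC6)C[C@H]5/C=C\CCCCNC(=O)N4C3)cc(-c3nc(C(C)C)cs3)nc2c1` gives 1.6 L/kg. These two numbers lie within the scatter of each other, so neither compound stands apart in this assay. Compound 3 `COc1ccc2c(O[C@@H]3C[C@H]4C(=O)N[C@]5(C(=O)NS(=O)(=O)C6CC6)C[C@H]5/C=C\CCCCN(C)C(=O)N4C3)cc(-c3nc(C(C)C)cs3)nc2c1` differs from compound 2 by methyl in place of hydrogen on an amide-type nitrogen in a ring. Going by the values given here, no step between measured compounds is available to guide this change. The step of no change at the digits printed from compound 2 to compound 3 (within the scatter) is expected to remain within the scatter, in no clear direction. Compound 3 is therefore expected to give 1.6 L/kg in this assay, with a range from 0.9 L/kg to 2.9 L/kg.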

Compound 3, volume of distribution: 4.5 L/kg
Estimate against measurement, compound 3: 2.8-fold (0.45 log units) below; measured number outside the range, above it.
By their numbers in this assay, from the lowest: compounds 1 and 2 (each within the scatter of the next); then compound 3.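

In this assay, methyl in place of hydrogen on the amide-type nitrogen in the 14-membered ring gives a 2.8-fold higher number from compound 2 to compound 3 (0.45 log units; beyond the scatter), a step beyond the scatter. Going by these compounds alone, the numbers of compound 1 and compound 2 lie within the scatter of each other, so only this change shows that the ring nitrogen is a place where the volume of distribution can move. Nothing measured here accounts for the rise. Going by these compounds, what stays open is whether ethyl or a hydroxyethyl group on this nitrogen would move the number further. Methyl on the same nitrogen of compound 1 could also give a different step.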